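Hydrazone series: trifluoromethylphenyl in place of quinolinyl

This account rests on a few compounds, and the source may have more. Where it says the series, first, only, none or still open, it means among the compounds named here.

In an assay on CHO-K1 cells for displacement of a labelled ligand from adenosine receptor A1 (Homo sapiens), read by scintillation counting, with a stated time of 60 min (a lower number here means a stronger inhibitor, a higher number a weaker inhibitor), compound 3 `Nc1nc(N/N=C/c2ccc3ncccc3c2)nc2c1ncn2[C@@H]1O[C@H](CO)[C@@H](O)[C@H]1O` gives 9.8 nM. Among the numbers of the series this is the highest; the nearest is compound 1 `CCCCC/C=C/C=C/C=N/Nc1nc(N)c2ncn([C@@H]3O[C@H](CO)[C@@H](O)[C@H]3O)c2n1`, which in this assay gives 2 nM, the step being a 4.9-fold higher number from compound 1 to compound 3 (0.69 log units; beyond the scatter). Compound 2 `CC(=O)Nc1ccc(/C=N/Nc2nc(N)c3ncn([C@@H]4O[C@H](CO)[C@@H](O)[C@H]4O)c3n2)cc1` gives in this assay only a limit, > 10000 nM. One of the three values thus sits at the limit of > 10000 nM in this assay, at which 1 of the 3 values shown sits. The step of an at least 1000-fold lower number from compound 2 to compound 3 (3.00 log units; beyond the scatter) is large.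

Compound 4 `Nc1nc(N/N=C/c2ccc(C(F)(F)F)cc2)nc2c1ncn2[C@@H]1O[C@H](CO)[C@@H](O)[C@H]1O` differs from compound 3 by 4-(trifluoromethyl)phenyl in place of quinolin-6-yl on a carbon with a double bond to nitrogen. Within the data shown here, two measured steps bear on it, both touching the same carbon with a double bond to nitrogen: moving from a substituted single six-membered aromatic ring to quinolin-6-yl was an at least 1000-fold lower number from compound 2 to compound 3 (3.00 log units; beyond the scatter), while moving from the open chain to quinolin-6-yl was a 4.9-fold higher number from compound 1 to compound 3 (0.69 log units; beyond the scatter). Compound 4 returns to a single six-membered aromatic ring carrying one substituent, as in compound 2, though with a different group. A large loss is therefore expected, the step of a 41-fold higher number from compound 3 to compound 4 (1.61 log units; beyond the scatter) being the estimate, with a real chance that only a limit is returned. Compound 4 is estimated at 400 nM, in the range 40 nM to 10000 nM.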

Compound 4, inhibition constant: 37 nM
Beside the measured number, compound 4's estimate is 11-fold (1.03 log units) above it, and the stated range ends above it.
By their numbers in this assay, from the lowest: compound 1; then compound 3; then compound 4. At a limit, above all of these: compound 2.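

In this assay a single six-membered aromatic ring on the carbon with a double bond to nitrogen can still give a low number: 4-(trifluoromethyl)phenyl in place of quinolin-6-yl costs only a modest step (a 3.8-fold higher number from compound 3 to compound 4 (0.58 log units; beyond the scatter)), so the second ring of quinolin-6-yl and its hetero atom are not required for a value in this range, although the open chain of compound 1 remains ahead (a 19-fold higher number from compound 1 to compound 4 (1.27 log units; beyond the scatter)). The heavy loss in compound 2 therefore goes with acetamido and not with the single ring as such, since trifluoromethyl in place of acetamido on an aromatic carbon gives a large step (an at least 270-fold lower number from compound 2 to compound 4 (2.43 log units; beyond the scatter)). The value of compound 2 is only a limit: the limit of > 10000 nM in this assay, at which 1 of the 4 values shown sits.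

Still open, from the compounds shown here alone, is whether a small amine, a carboxylic acid or a nitrile in place of trifluoromethyl on that aromatic carbon tracks compound 4 or compound 2. The compounds shown also do not tell why acetamido and trifluoromethyl differ so widely, or whether a longer open chain would hold the number of compound 1.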